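The source may hold more compounds than are shown below. What is called first, only, known or untested is meant among the compounds shown, and "the series" means these compounds.

In an assay on HEK293 cells for inhibition of steroid 17-alpha-hydroxylase/17,20 lyase (Homo sapiens), read by scintillation proximity assay, using microsomes and NADPH, with a stated time of 45 min (on this read-out lower numbers stand for stronger inhibition and higher numbers for weaker inhibition), compound 3 `Cc1ccncc1-c1cccc2c1cnn2-c1ccc(F)cc1` gives 5 nM, the largest of the three numbers shown, although its gaps to the other two lie within the scatter: compound 1 `Cc1ccncc1-c1cccc2c1cnn2-c1nccs1` gives 4 nM and compound 2 `Cc1ccncc1-c1cccc2c1cnn2-c1ccccc1` gives 4 nM. Compound 4 `Cc1ccncc1-c1cccc2c1cnn2-c1ccccn1` differs from compound 3 by pyridin-2-yl in place of 4-fluorophenyl on an aromatic nitrogen. The measured steps that bear on this change all exchange the group on the same aromatic nitrogen: a 1.3-fold higher number from compound 1 to compound 3 (0.10 log units; within the scatter), a 1.3-fold higher number from compound 2 to compound 3 (0.10 log units; within the scatter) and no change at the digits printed from compound 1 to compound 2 (within the scatter), none of them beyond the scatter. On that basis compound 4 is expected to show no step beyond the scatter in this assay, no change at the digits printed from compound 3 to compound 4 (within the scatter). The estimate for compound 4 is therefore 5 nM, with a range from 2 nM to 12 nM.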

Compound 4, half-maximal inhibitory concentration: 2 nM
Compound 4: the middle estimate sits 2.5-fold (0.40 log units) above what was measured, and the stated range covers the measured number.
By their numbers in this assay, from the lowest: compounds 4, 1, 2 and 3 (each within the scatter of the next, the first and the last beyond it).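

In this assay, among the compounds shown here, exchanging the group on this aromatic nitrogen had so far left the number within the scatter, and pyridin-2-yl gives the first step beyond it, with a 2.5-fold lower number from compound 3 to compound 4 (0.40 log units; beyond the scatter). The step is modest and holds only against 4-fluorophenyl, while a 2.0-fold lower number from compound 2 to compound 4 (0.30 log units; within the scatter) and a 2.0-fold lower number from compound 1 to compound 4 (0.30 log units; within the scatter) both stay within the scatter. No measurement given here accounts for the step. The compounds shown leave open how an amine or a carboxylic acid on the pyridin-2-yl ring would read in this assay.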